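Hydrazone series: trimming the aryl hydrazone to methylene

The compounds below may be only part of what the source reports. "The series", "measured", "known", "first", "only" and "open" are said of these compounds alone.

Measured so far:
compound 1 `Oc1ccc(/C=N/Nc2nc3ccccc3nc2Cc2ccccc2)cc1`, an assay on isolated protein for inhibition of Amine oxidase [flavin-containing] B (Homo sapiens), read by spectrophotometry (on this read-out lower numbers stand for stronger inhibition and higher numbers for weaker inhibition), 7900000 nM
compound 2 `O=[N+]([O-])c1ccc(/C=N/Nc2nc3ccccc3nc2Cc2ccccc2)cc1`, this assay 960000 nM

Compound 1 carries the highest number of the two measured; its nearest neighbour is compound 2, reached by an 8.2-fold lower number from compound 1 to compound 2 (0.92 log units; beyond the scatter), with nitro in place of hydroxy on an aromatic carbon.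

Compound 3 `C=NNc1nc2ccccc2nc1Cc1ccccc1` is not yet measured. It differs from compound 1 by a group of 2 heavy atoms (1 carbon, 1 nitrogen; no ring) in place of a group of 9 heavy atoms (7 carbon, 1 nitrogen, 1 oxygen; one six-membered aromatic ring of carbon only), on a nitrogen on an aromatic ring.

Among the measured compounds shown here, the only measured step, an 8.2-fold lower number from compound 1 to compound 2 (0.92 log units; beyond the scatter), swaps a substituent on that ring rather than removing the ring, so it bears on this change only loosely; it shows that the aryl end is sensitive to alteration. For the measured compounds named here, with the ring gone, no measured step supports a gain. Compound 3 is expected at 15000000 nM (range 3000000 nM to 70000000 nM), meaning an expected step of a 1.9-fold higher number from compound 1 to compound 3 (0.28 log units; within the scatter), and the measurement may well return only a limit.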

Compound 3, half-maximal inhibitory concentration: 950000 nM
Compound 3: the middle estimate sits 16-fold (1.20 log units) above what was measured; measured number below the stated range.
By their numbers in this assay, from the lowest: compounds 3 and 2 (each within the scatter of the next); then compound 1.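

In this assay, putting the group of 2 heavy atoms in place of the group of 9 heavy atoms, on a nitrogen on an aromatic ring, gives an 8.3-fold lower number from compound 1 to compound 3 (0.92 log units; beyond the scatter), so the six-membered aromatic ring of carbon only is not needed to reach a lower number than compound 1. Compound 2 at 960000 nM and compound 3 at 950000 nM lie within the scatter of each other, which leaves compound 1, the hydroxy compound, as the one that stands apart. Nothing available explains either step, with no supporting data on why the hydroxy compound gives the highest number.

Open, as far as these compounds go, is whether an amine or a longer chain on that nitrogen would hold this level or move beyond it. Also open, from the compounds shown here alone, is how much of the reading the shared core carries alone.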